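The source may hold more compounds than are shown below. What is called first, only, known or untested is meant among the compounds shown, and "the series" means these compounds.

Measured compounds in a functional assay on A549 cells (Homo sapiens) for cytotoxicity, read by MTT assay, with a stated time of 48 h; on this read-out lower numbers stand for stronger inhibition and higher numbers for weaker inhibition:

- compound 1, `CCOC(=O)c1c(-c2cc3ccccc3oc2=O)nn(-c2ccccc2)c1C(=O)OCC`: 100000 nM
- compound 2, `CCOC(=O)c1c(-c2cc3ccccc3oc2=O)nn(-c2ccc(C)c(C)c2)c1C(=O)OCC`: 52000 nM
- compound 3, `CCOC(=O)c1c(-c2cc3ccccc3oc2=O)nn(-c2cccc(Cl)c2)c1C(=O)OCC`: 28000 nM

Compound 3 gives the lowest of the three numbers in this assay. Its nearest neighbour is compound 2, with a step of a 1.9-fold lower number from compound 2 to compound 3 (0.27 log units; within the scatter); the furthest is compound 1, with a step of a 3.6-fold lower number from compound 1 to compound 3 (0.55 log units; beyond the scatter). Only the last of these is beyond the scatter, so compound 3 is separated from compound 1 but not clearly from compound 2.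

Compound 4, `CCOC(=O)c1c(-c2cc3ccccc3oc2=O)nn(-c2ccc(Cl)cc2)c1C(=O)OCC`, differs from compound 3 in the group on the aromatic nitrogen: 4-chlorophenyl in place of 3-chlorophenyl on an aromatic nitrogen. The two compounds share every atom and differ only in the position of the chlorine on that phenyl ring.

Going by the values given here, no measured step moves a chlorine from one position to another on this ring. Among the compounds with values here, the steps that bear on the aromatic nitrogen substituent are a 1.9-fold lower number from compound 1 to compound 2 (0.28 log units; within the scatter), a 3.6-fold lower number from compound 1 to compound 3 (0.55 log units; beyond the scatter) and a 1.9-fold lower number from compound 2 to compound 3 (0.27 log units; within the scatter); together they show that changes on this ring have so far shifted the number by modest amounts only, with one step beyond the scatter. On that basis the expected step in this assay for compound 4 is no change at the digits printed from compound 3 to compound 4 (within the scatter), i.e. none beyond the scatter in either direction. Compound 4 is therefore estimated at 28000 nM, with a range from 10000 nM to 80000 nM.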

Compound 4, half-maximal inhibitory concentration: 35000 nM
Estimate against measurement, compound 4: 1.3-fold (0.10 log units) below, within the range that was stated.
By their numbers in this assay, from the lowest: compounds 3, 4, 2 and 1 (each within the scatter of the next, the first and the last beyond it).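

In this assay, going by these compounds alone, the change to 4-chlorophenyl in place of 3-chlorophenyl on the aromatic nitrogen gives a 1.3-fold higher number from compound 3 to compound 4 (0.10 log units; within the scatter), the first direct comparison of two chlorine placements on this ring, and the two are not told apart on this read-out. Chloro in place of hydrogen gives a 2.9-fold lower number from compound 1 to compound 4 (0.46 log units; beyond the scatter), which matches a 3.6-fold lower number from compound 1 to compound 3 (0.55 log units; beyond the scatter) in lying beyond the scatter, so the separation from compound 1 holds for both chlorinated compounds, while 4-chlorophenyl in place of 3,4-dimethylphenyl gives a 1.5-fold lower number from compound 2 to compound 4 (0.17 log units; within the scatter), leaving compound 4, like compound 3, not clearly separated from compound 2. Nothing in hand offers an explanation for these steps in this assay.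

The compounds shown carry only chloro or methyl on this phenyl ring, so it remains open whether a methoxy group, an amine or a carboxylic acid there would shift the number further than these modest steps. The two ethoxycarbonyl groups are also common to all four compounds, which leaves open what a carboxylic acid or an amide in their place would do in this assay.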